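The source may hold more compounds than are shown below. What is called first, only, known or untested is meant among the compounds shown, and "the series" means these compounds.

Compound 3 `Cc1cn(C2CC(N=[N+]=[N-])C(COC(=O)NCCCN)O2)c(=O)[nH]c1=O` gives only a limit in an ADME assay on the whole organism (serum) with Homo sapiens as the target (a lower number here means that the compound disappears faster, a higher number that the compound lasts longer), namely > 48 h. It sits at the limit of > 48 h in this assay, at which 1 of the 3 values shown sits, so its true number is not known, only its floor. Compound 1 `Cc1cn(C2CC(N=[N+]=[N-])C(COC(=O)OCCCCO)O2)c(=O)[nH]c1=O` gives 0.5 h in this assay, and compound 2 `CCCCOC(=O)OCC1OC(n2cc(C)c(=O)[nH]c2=O)CC1N=[N+]=[N-]` gives 0.15 h. Compound 4 `Cc1cn(C2CC(N=[N+]=[N-])C(COC(=O)OCCCCCO)O2)c(=O)[nH]c1=O` has not yet been measured; it differs from compound 3 by (5-hydroxypentyl)oxy in place of (3-aminopropyl)amino on a carbonyl carbon.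

Within the data shown here, two measured steps bear directly on this change, both running the opposite way through the same carbonyl carbon: an at least 96-fold higher number from compound 1 to compound 3 (1.98 log units; beyond the scatter) and an at least 320-fold higher number from compound 2 to compound 3 (2.50 log units; beyond the scatter). A third, a 3.3-fold lower number from compound 1 to compound 2 (0.52 log units; beyond the scatter), shows that a hydroxy group on the chain shifts the number only modestly by comparison. Reversing the move to the (3-aminopropyl)amino group is therefore expected to undo most of that large rise, and a one-carbon longer hydroxyalkyl chain is not expected to alter that much. The expected step is an at least 80-fold lower number from compound 3 to compound 4 (1.90 log units; beyond the scatter). Compound 4 is estimated at 0.6 h, with a range from 0.2 h to 2 h.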

Compound 4, half-life: 0.267 h
Compound 4: middle estimate off by 2.2-fold (0.35 log units), on the high side; low and high end bracket the measured number.
By their numbers in this assay, from the lowest: compounds 2, 4 and 1 (each within the scatter of the next, the first and the last beyond it). At a limit, above all of these: compound 3.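

In this assay, (5-hydroxypentyl)oxy in place of (3-aminopropyl)amino on a carbonyl carbon gives an at least 170-fold lower number from compound 3 to compound 4 (2.25 log units; beyond the scatter), so a third chain joined through oxygen falls far short of compound 3. The value of compound 3 is a limit: the limit of > 48 h in this assay, at which 1 of the 4 values shown sits.

The hydroxymethyl change gives a 1.8-fold higher number from compound 2 to compound 4 (0.25 log units; within the scatter) and a 1.9-fold lower number from compound 1 to compound 4 (0.27 log units; within the scatter), both within the scatter, so compound 4 cannot be told apart from either neighbour, even though compound 1 and compound 2 are separated beyond the scatter.

The (3-aminopropyl)amino group differs from these chains both in the atom joined to the carbonyl carbon and in the amine it carries, and the compounds shown do not separate the two. An amine on a chain joined through oxygen, or a hydroxy chain joined through nitrogen, would do so.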